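From 2-methoxyphenyl to benzyl on the shared core

The source may hold more compounds than are shown below. What is called first, only, known or untested is meant among the compounds shown, and "the series" means these compounds.

For the measured compounds named here, in a functional assay on HT-29 cells (Homo sapiens) for antiproliferative activity, read by MTT assay, with a stated time of 48 h (on this read-out higher numbers stand for an effect only at larger amounts of compound and lower numbers for an effect already at smaller amounts), compound 2 `COc1ccccc1-n1c(SCC(=O)Nc2nc3ccc(C)cc3s2)nc2c(c1=O)SCC2` gives 340 nM, the only actual number so far. Compound 1 `Cc1ccc2nc(NC(=O)CSc3nc4c(c(=O)n3-c3ccc(F)cc3)SCC4)sc2c1` reads > 10000 nM, which is a limit. Compound 3 `Cc1ccc2nc(NC(=O)CSc3nc4c(c(=O)n3Cc3ccccc3)SCC4)sc2c1` has benzyl in place of 2-methoxyphenyl on an aromatic nitrogen. Going by the values given here, one measured step bears on this place: an at least 29-fold lower number from compound 1 to compound 2 (1.46 log units; beyond the scatter), a large change that came with 2-methoxyphenyl replacing 4-fluorophenyl. With 2-methoxyphenyl gone again, a moderate move to a higher number is expected in this assay. The expected step is a 5.3-fold higher number from compound 2 to compound 3 (0.72 log units; beyond the scatter). For compound 3 the estimated value is 1800 nM, within an expected range from 300 nM to 9000 nM.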

Compound 3, half-maximal effective concentration: > 10000 nM
Compound 3: a limit, no number; the forecaster's own chance of this, stated with the estimate: 25%; at least 5.5-fold (0.74 log units) between middle value and limit.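

With benzyl on the aromatic nitrogen, this assay shows an at least 29-fold higher number from compound 2 to compound 3 (1.46 log units; beyond the scatter). Retaining a six-membered aromatic ring of carbon is therefore not enough for a measurable number here, and of the three groups shown at this position, only 2-methoxyphenyl gives one. The step between compound 1 and compound 3 cannot be read, as both values are limits: the limit of > 10000 nM in this assay, at which 2 of the 3 values shown sit. The compounds shown leave open whether 2-hydroxyphenyl, 2-methylphenyl or 4-methoxyphenyl on this nitrogen would also give a number rather than a limit.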